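This account rests on a few compounds, and the source may have more. Where it says the series, first, only, none or still open, it means among the compounds named here.

Compound 1 `O=C(/C=C/c1cccs1)c1cccc(OCC2CO2)c1`: in an assay for inhibition of DNA topoisomerase 1 (Homo sapiens), with a stated time of 30 min, tested at 20 uM (a higher number here means a stronger effect of the compound at the concentration tested, a lower number a weaker effect), compound 1 gives "not determined" (no result reported).
Compound 2 `O=C(/C=C/c1ccco1)c1ccc(OCC2CO2)cc1`: in this assay compound 2 gives 0%.

Compound 2 thus stands at the only number shown, with compound 1 adding nothing numerical. Compound 3 `O=C(/C=C/c1ccsc1)c1ccc(OCC2CO2)cc1` differs from compound 2 in one place: thiophen-3-yl in place of furan-2-yl on a double-bonded chain carbon bound to a double-bonded chain carbon. No step between measured compounds exists to guide this change, so no direction can be drawn from the shown values. Because compound 2 gives 0%, compound 3 is expected to give 5%, within a range of 0% to 20%, meaning an expected step of a number 5 percentage points higher from compound 2 to compound 3 (within the scatter) that does not go beyond the scatter.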

Compound 3, a percentage reported as inhibition, at one concentration (the size of the read-out at that concentration, not a potency): 0%
For compound 3 the middle estimate is 5 percentage points above the measured one; measured number inside the range.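

Among the compounds shown here, with thiophen-3-yl in place of furan-2-yl on a double-bonded chain carbon bound to a double-bonded chain carbon, this assay shows no change at the digits printed from compound 2 to compound 3 (within the scatter) and gives the first reading of a change at this position. This exchange of one five-membered aromatic ring for another, sulfur for oxygen, leaves compound 3 with the same read-out as compound 2. Nothing at hand bears on why this is so.

On these data alone, it remains open whether an amine or a carboxylic acid at this place would give a different read-out in this assay. Compound 1 gives "not determined" (no result reported) and so offers no comparison.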